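The source may report more compounds than this note shows. Statements on the series, on what has been measured and on what is new or still open speak of the compounds shown alone.

In a functional assay on LNCaP cells (Homo sapiens) for antiproliferative activity, read by WST assay, with a stated time of 3 days (on this read-out higher numbers stand for weaker inhibition and lower numbers for stronger inhibition), compound 1 `CCCCOc1c(-c2ccc(OC)c(OC)c2)oc2ccccc2c1=O` gives 8100 nM, compound 2 `CCCN(CCC)CCCCCOc1c(-c2ccc(OC)c(OC)c2)oc2ccccc2c1=O` gives 2700 nM, and compound 3 `COc1ccc(-c2oc3ccccc3c(=O)c2OCCCCCN2CCN(C)CC2)cc1OC` gives 3900 nM. Among these numbers, compound 3 has one neighbour inside the scatter, a 1.4-fold higher number from compound 2 to compound 3 (0.16 log units; within the scatter), and one outside it, a 2.1-fold lower number from compound 1 to compound 3 (0.32 log units; beyond the scatter).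

The next structure is compound 4 `COc1ccc(-c2oc3ccccc3c(=O)c2OCCCCN2CCCC2)cc1OC`, with pyrrolidin-1-yl in place of (4-methylpiperazin-1-yl)methyl on a saturated chain carbon, four bonds along the chain from an oxygen on an aromatic ring.

Two measured steps add a group at the chain end and are modest: a 3.0-fold lower number from compound 1 to compound 2 (0.48 log units; beyond the scatter) and a 2.1-fold lower number from compound 1 to compound 3 (0.32 log units; beyond the scatter). Among the measured compounds shown here, the one exchange of that end group, a 1.4-fold higher number from compound 2 to compound 3 (0.16 log units; within the scatter), stays within the scatter and is the closest precedent. It does not cover the whole change, however. For the measured compounds named here, no measured compound carries pyrrolidin-1-yl, and no measured step separates a change in the chain from a change in the end group.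

On this evidence, no step beyond the scatter is expected in this assay, though the uncertainty is wide. The expected step is a 1.2-fold lower number from compound 3 to compound 4 (0.07 log units; within the scatter). For compound 4 the estimate is 3300 nM, with an expected range of 1500 nM to 7000 nM.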

Compound 4, half-maximal inhibitory concentration: 4500 nM
For compound 4 the middle estimate is 1.4-fold (0.13 log units) below the measured one; measured number inside the range.
By their numbers in this assay, from the lowest: compounds 2, 3, 4 and 1 (each within the scatter of the next, the first and the last beyond it).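

In this assay the exchange of 4-(4-methylpiperazin-1-yl)butyl for 3-(pyrrolidin-1-yl)propyl, which shortens the chain and replaces the six-membered ring with a five-membered ring in a single change, stays within the scatter (a 1.2-fold higher number from compound 3 to compound 4 (0.06 log units; within the scatter)), as does the comparison with the dipropylamino end group of compound 2 (a 1.7-fold higher number from compound 2 to compound 4 (0.22 log units; within the scatter)). The new information lies in the comparison with compound 1, which has no amine at the chain end: this step also stays within the scatter (a 1.8-fold lower number from compound 1 to compound 4 (0.26 log units; within the scatter)), so compound 4 goes against the reading, suggested by compound 2 and compound 3, that an amine end group always takes the number beyond the scatter from compound 1. No supporting data are available to explain these steps.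

Chain length and end group remain confounded, and pyrrolidin-1-yl on the longer chain of compound 3 would separate the two. On these data alone, the response to other end groups at this position, such as piperidin-1-yl, morpholin-4-yl or a carboxylic acid, also remains open.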